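Swapping 2-fluorophenyl for 3-nitrophenyl on the benzylpiperidine arm

A few compounds are considered here, and "the series" means these few. Any claim that something is new, unique, unknown or untested is made for them only; others in the source may bear on it.

compound 1 `CC(C)(C)c1cc(C(=O)NCCC2CCN(Cc3ccccc3)CC2)cc(C(C)(C)C)c1O` — 89200 nM
compound 2 `CC(C)(C)c1cc(/C=C/C(=O)NCCC2CCN(Cc3ccccc3F)CC2)cc(C(C)(C)C)c1O` — 7400 nM

In an assay on isolated protein for inhibition of Amine oxidase [flavin-containing] B (Homo sapiens), read by fluorescence, with stated times of 15 min and 20 min (on this read-out higher numbers stand for weaker inhibition and lower numbers for stronger inhibition), compound 2 gives 7400 nM, the lower of the two numbers, and its gap to compound 1 lies beyond the scatter. Compound 3 `CC(C)(C)c1cc(/C=C/C(=O)NCCC2CCN(Cc3cccc([N+](=O)[O-])c3)CC2)cc(C(C)(C)C)c1O` is not yet measured and differs from compound 2 in one place: 3-nitrophenyl in place of 2-fluorophenyl on a saturated chain carbon bound to an amine nitrogen in a ring. Within the data shown here, no measured pair shows this change, so the step cannot be read from the data; a step of small size in either direction, or none beyond the scatter, is expected. For compound 3 the estimate in this assay is 6000 nM, with a range from 1500 nM to 25000 nM. This corresponds to an expected 1.2-fold lower number from compound 2 to compound 3 (0.09 log units; within the scatter).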

Compound 3, half-maximal inhibitory concentration: 12500 nM
The estimate for compound 3 lay 2.1-fold (0.32 log units) below the measured number, and the stated range covers the measured number.
By their numbers in this assay, from the lowest: compounds 2 and 3 (each within the scatter of the next); then compound 1.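

In this assay, 3-nitrophenyl in place of 2-fluorophenyl on this saturated chain carbon gives a 1.7-fold higher number from compound 2 to compound 3 (0.23 log units; within the scatter), so compound 2 and compound 3 cannot be told apart. This position therefore holds either group, including one with 2 hydrogen-bond acceptors, with no change beyond the scatter. Nothing measured here bears on this result. On these data alone, both the substituent and its place on the aromatic ring differ at once, so the separate contribution of each remains open. As far as these compounds go, whether an amine or a carboxylic acid on that ring would shift the number also remains open.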